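Swapping 3,5-difluorophenyl for 2,4,5-trifluorophenyl

The source may report more compounds than this note shows. Statements on the series, on what has been measured and on what is new or still open speak of the compounds shown alone.

Of the compounds shown here, two have numbers so far in a functional assay with Homo sapiens as the target; a lower number here means a stronger inhibitor, a higher number a weaker inhibitor. Compound 1 (`CC(C)[C@H](NC(=O)COc1cccc2ccccc12)C(=O)N[C@@H](CC(=O)O)C(=O)COc1ccc2ccccc2c1`) gives 15900 nM, and compound 2 (`CC(C)[C@H](NC(=O)COc1cccc2ccccc12)C(=O)N[C@@H](CC(=O)O)C(=O)COc1cc(F)cc(F)c1`) gives 15900 nM, level with it. Next comes compound 3 (`CC(C)[C@H](NC(=O)COc1cccc2ccccc12)C(=O)N[C@@H](CC(=O)O)C(=O)COc1cc(F)c(F)cc1F`), with 2,4,5-trifluorophenyl in place of 3,5-difluorophenyl on an oxygen on a saturated carbon. Among the measured compounds shown here, the only measured step at this place is no change at the digits printed from compound 1 to compound 2 (within the scatter), with 3,5-difluorophenyl in place of naphthalen-2-yl. That single step is thin evidence, and no change in fluorine count has been measured on its own. Even so, nothing measured points to a shift beyond the scatter in this assay, and no direction is favoured. The expected step is a 1.1-fold lower number from compound 2 to compound 3 (0.06 log units; within the scatter), within the scatter. Compound 3 is estimated at 14000 nM, with an expected range of 5000 nM to 32000 nM.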

Compound 3, half-maximal inhibitory concentration: 16700 nM
Compound 3: the middle estimate sits 1.2-fold (0.08 log units) below what was measured, and the stated range covers the measured number.
By their numbers in this assay, from the lowest: compounds 1, 2 and 3 (each within the scatter of the next).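

In this assay, 2,4,5-trifluorophenyl in place of 3,5-difluorophenyl on the oxygen gives a 1.1-fold higher number from compound 2 to compound 3 (0.02 log units; within the scatter), a change in fluorine count that the earlier pair did not include. Set against naphthalen-2-yl, the same group gives a 1.1-fold higher number from compound 1 to compound 3 (0.02 log units; within the scatter), so all three groups at this place now lie within the scatter of one another, whether the ring is fluorinated or not. No measurement at hand offers an explanation for this flat reading.

Still open, on these data alone, is whether the reading holds for a group at this place that is not an aromatic ring, such as an amine or a carboxylic acid on a longer chain. Also open, as far as these compounds go, is whether a change elsewhere on the shared core would move the number in this assay.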